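The compounds below may be only part of what the source reports. "The series", "measured", "known", "first", "only" and "open" are said of these compounds alone.

Measured compounds in an assay on HEK293 cells for inhibition of acid ceramidase (Homo sapiens), with a stated time of 10 min; a higher number here means a weaker inhibitor, a lower number a stronger inhibitor:
compound 1 `O=C(NCCCCc1ccccc1)n1c(=O)oc2ccccc21`: 64 nM
compound 3 `O=C(NCCCc1ccccc1)n1c(=O)oc2ccccc21`: 55 nM
compound 2 `Cc1cccc2oc(=O)n(C(=O)NCCCCc3ccccc3)c12`: no result reported

Compound 1 stands highest of the two numbers available in this assay; its nearest neighbour is compound 3, and the step of a 1.2-fold lower number from compound 1 to compound 3 (0.07 log units; within the scatter) lies within the scatter, so the two cannot be ordered. Compound 2 carries a methyl on the core and gives no number.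

Compound 4 `O=C(NCCCCc1ccccc1)n1c(=O)oc2ccc(-c3ccccc3)cc21` differs from compound 1 by phenyl in place of hydrogen on an aromatic carbon. Within the data shown here, the one step measured so far, a 1.2-fold lower number from compound 1 to compound 3 (0.07 log units; within the scatter), concerns the chain rather than the core, and it is within the scatter; nothing measured here touches the aromatic carbon in question, so no step can be drawn on for a direction. The expectation for compound 4 is therefore a number close to compound 1, with a broad range to either side: the expected step is a 1.1-fold lower number from compound 1 to compound 4 (0.03 log units; within the scatter), not beyond the scatter. Compound 4 is estimated at 60 nM, with a range from 15 nM to 250 nM.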

Compound 4, half-maximal inhibitory concentration: 42 nM
Compound 4: the middle estimate sits 1.4-fold (0.15 log units) above what was measured, within the range that was stated.
By their numbers in this assay, from the lowest: compounds 4, 3 and 1 (each within the scatter of the next).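

In this assay, among these compounds, phenyl in place of hydrogen on an aromatic carbon gives the first readable change to the shared core, and the step (a 1.5-fold lower number from compound 1 to compound 4 (0.18 log units; within the scatter)) cannot be told apart from no change. Among the compounds shown here, until now, the only readable step concerned the chain, so this is the first sign that the core of compound 1 can take a substituent on this carbon, meta to a fused ring and para to a fused ring, without a change in the number beyond the scatter. Nothing available explains this result.

Still open, going by these compounds, is whether an amine, a carboxylic acid or a methoxy group on this same aromatic carbon would also leave the number within the scatter. Also open, on these data alone, is whether phenyl on this carbon would give a similar number when paired with the chain of compound 3.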